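The source may report more compounds than this note shows. Statements on the series, on what has been measured and on what is new or still open speak of the compounds shown alone.

Series notes. Compound 1 `NC(=O)c1cccc(-c2ccc3oc(NC4CCCCC4)nc3c2)c1` in an assay on HEK293 cells for inhibition of Fatty-acid amide hydrolase 1 (Homo sapiens), read by fluorescence (on this read-out lower numbers stand for stronger inhibition and higher numbers for weaker inhibition), gives only a limit of the assay, > 1000 nM. Compound 2 `c1cc2cc(-c3ccc4oc(NC5CCCCC5)nc4c3)cnc2[nH]1` likewise gives only a limit, > 1000 nM. Among the compounds with values here, compound 3 `Cn1ccc2cc(-c3ccc4oc(Cc5ccccc5)nc4c3)ccc21` is the sole member with a number, at 488 nM in this assay. Otherwise the set shows (the limit of > 1000 nM in this assay, at which 2 of the 3 values shown sit). Compound 4 `Cn1ccc2cc(-c3ccc4oc(N5CCNCC5)nc4c3)ccc21` is not yet measured. It differs from compound 3 by piperazin-1-yl in place of benzyl on an aromatic carbon. Within the data shown here, no measured pair here shares this change, so the size of the step from compound 3 to compound 4 in this assay rests on the position of compound 3 alone. The expected step from compound 3 to compound 4 is a 3.1-fold higher number from compound 3 to compound 4 (0.49 log units; beyond the scatter), a weakening beyond the scatter. Compound 4 is estimated at 1500 nM, in the range 500 nM to 5000 nM.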

Compound 4, half-maximal inhibitory concentration: > 1000 nM
Compound 4 gave a limit, no number; the forecaster's own chance of this, stated with the estimate: 55%; the middle value lies beyond the limit too.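

In this assay, within the data shown here, piperazin-1-yl in place of benzyl on an aromatic carbon gives an at least 2.0-fold higher number from compound 3 to compound 4 (0.31 log units; beyond the scatter), the first step that can be read at this position. Compound 4 gives only a limit of the assay, > 1000 nM. Benzyl in compound 3 thus remains the only group at this position with a number, and the series mostly sits at the limit: the limit of > 1000 nM in this assay, at which 3 of the 4 values shown sit.

As far as these compounds go, how far compound 4 lies past its limit stays open, so the full size of the step cannot be read. Also open, from the compounds shown here alone, is how morpholin-4-yl, or a longer chain such as phenylethyl, would read at this position.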